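A few compounds are considered here, and "the series" means these few. Any claim that something is new, unique, unknown or untested is made for them only; others in the source may bear on it.

In a functional assay on HT-29 cells (Homo sapiens) for antiproliferative activity, read by sulforhodamine B assay, with a stated time of 72 h (a lower number here means a stronger inhibitor, a higher number a weaker inhibitor), compound 1 `O=C1CS/C(=N/Nc2nncc3ccccc23)N1c1ccccc1` reads 47 nM and compound 3 `COc1ccc(NC(=S)NNc2nncc3ccccc23)cc1` reads 20 nM on the same scale. Compound 2 `Cc1cc(C)nc(NS(=O)(=O)c2ccc(Nc3nncc4ccccc34)cc2)n1` reads 3.3 nM and is the strongest inhibitor of these three, and the numbers of both others lie above it by more than the usual scatter of repeated measurements.

Compound 4 `O=S(=O)(Nc1ccccn1)c1ccc(Nc2nncc3ccccc23)cc1` has not been measured yet. It keeps the shared core and the sulfonamide of compound 2 and alters one group, with pyridin-2-yl in place of 4,6-dimethylpyrimidin-2-yl on a sulfonamide nitrogen. Counted out, the change reads pyridin-2-yl in place of 4,6-dimethylpyrimidin-2-yl on a sulfonamide nitrogen and the rest of the molecule stays the same.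

Among the measured compounds shown here, no two measured compounds differ in just one place, so the data give no direct guide to the size of this step. Compound 2 holds the lowest number at 3.3 nM and this leaves a new relative more room to land higher than lower, so a small loss of strength is the likelier outcome. The expected change is a 2.4-fold higher number from compound 2 to compound 4 (0.38 log units; beyond the scatter) and a result within the scatter would not be surprising. The estimated value for compound 4 is 8 nM with an expected range from 2.5 nM to 25 nM for the measurement still to come.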

Compound 4, half-maximal inhibitory concentration: 38 nM
Compound 4: the middle estimate sits 4.8-fold (0.68 log units) below what was measured, and the stated range ends below it.
By their numbers in this assay, from the lowest: compound 2; then compounds 3, 4 and 1 (each within the scatter of the next, the first and the last beyond it).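

In this assay, the group on the sulfonamide nitrogen proves to have a large influence: pyridin-2-yl in place of 4,6-dimethylpyrimidin-2-yl gives a 12-fold higher number from compound 2 to compound 4 (1.06 log units; beyond the scatter), the only direct reading of a single change among these compounds. The rest of the molecule stays the same, so this loss of strength belongs to the exchange of these two groups, even though both are six-membered aromatic rings without net charge; the entering group has 6 heavy atoms and 1 ring hetero atom, against 8 heavy atoms and 2 ring hetero atoms in the group it replaces. No measurement here explains why this exchange costs so much strength.

As far as these compounds go, the exchange alters the ring nitrogens and the methyl groups together, so their separate shares remain open, and an unsubstituted pyrimidin-2-yl group on the same nitrogen would help to tell them apart. From the compounds shown here alone, how a simple phenyl group or a morpholine ring would read at this position also remains open.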